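Removing the methoxy from compound 3: expected growth inhibition

This account rests on a few compounds, and the source may have more. Where it says the series, first, only, none or still open, it means among the compounds named here.

Three amides and ureas on the shared core have been run in a functional assay on MDA-MB-231 cells (Homo sapiens) for antiproliferative activity, read by sulforhodamine B assay (a lower number here means a stronger inhibitor of growth, a higher number a weaker inhibitor of growth), so far, and none has yet given a number. Compound 1, `COc1ccc2sc(NC(=O)c3ccc(C(F)(F)F)cc3)nc2c1`, reaches only the limit > 10 ug/mL in this assay. Compound 2, `COc1ccc2nc(NC(=O)c3ccc(C)cc3)sc2c1`, likewise stops at the limit > 10 ug/mL in this assay. Compound 3, `COc1ccccc1NC(=O)Nc1nc2ccc(F)cc2s1`, also sits at the limit > 10 ug/mL in this assay. Among the compounds with values here, the whole set therefore rests on (the limit of > 10 ug/mL in this assay, at which 3 of the 3 values shown sit), so no step between measured compounds can be sized, and no direction for any structural change can be read from the series.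

Compound 4 is `O=C(Nc1ccccc1)Nc1nc2ccc(F)cc2s1`. It differs from compound 3 by hydrogen in place of methoxy on an aromatic carbon; the methoxy leaves and hydrogen enters on an aromatic carbon of a six-membered aromatic ring of carbon only, ortho to a large group.

With compound 3 at a limit, the step to compound 4 in this assay cannot be anchored to a measured value, and nothing among the three measured compounds shows that the loss of a methoxy moves growth inhibition either way. The working expectation is that compound 4 stays near the limit, with the step that the limit leaves unreadable from compound 3 to compound 4 expected to fall within the scatter. Compound 4 is estimated at 15 ug/mL in this assay, within a range from 5 ug/mL to 50 ug/mL, and the read-out is expected most likely to be a limit again rather than a number.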

Compound 4, concentration for 50% growth inhibition: > 10 ug/mL
Compound 4 was reported as a limit; the forecaster's own chance of this, stated with the estimate: 80%; the middle value does not contradict the limit.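

Compound 3 and compound 4 both stand at a limit in this assay and give no number, so the exchange of methoxy for hydrogen yields no readable step: the limit of > 10 ug/mL in this assay, at which 4 of the 4 values shown sit.

The compounds shown leave open whether any change on the shared core brings growth inhibition to a measurable value, and in which direction methoxy acts.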